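The source may hold more compounds than are shown below. What is called first, only, known or untested is meant among the compounds shown, and "the series" means these compounds.

Of the compounds shown here, three sharing a core have been tested in a functional assay on MDA-MB-231 cells (Homo sapiens) for inhibition, read by MTT assay, with a stated time of 48 h; a lower number here means a stronger inhibitor, a higher number a weaker inhibitor. Compound 1 `COc1cc(C2=NOC(c3c[nH]c4ccccc34)C2)cc(OC)c1OC` gives 11700 nM. Compound 3 `Clc1ccc(Cn2cc(C3CC(c4ccncc4)=NO3)c3ccccc32)cc1` gives 13700 nM, a number so close to that of compound 1 that the two cannot be told apart within the usual scatter. Compound 2 `Cc1[nH]c2ccccc2c1C1CC(c2ccncc2)=NO1` gives 26600 nM, a weaker result than compound 1 by a margin that lies beyond the scatter.

The next compound, compound 4 `COc1ccc(C2=NOC(c3c[nH]c4ccccc34)C2)cc1OC`, differs from compound 1 in one place: hydrogen in place of methoxy on an aromatic carbon. Among the measured compounds shown here, no pair of measured compounds shows this particular change, so there is no measured step to lean on. For the measured compounds named here, compound 1 is the natural starting point, and the only guidance is that a loss of one methoxy group is a small change in size.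

The expected step from compound 1 to compound 4 is a 1.5-fold higher number from compound 1 to compound 4 (0.16 log units; within the scatter), a mild weakening that may well fall within the scatter. Compound 4 is therefore estimated at 17000 nM in this assay, with a plausible range from 6000 nM to 48000 nM.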

Compound 4, half-maximal inhibitory concentration: > 100000 nM
Compound 4: no number, only a limit; the forecaster's own chance of this, stated with the estimate: 10%; middle value at least 5.8-fold (0.76 log units) from the limit.
By their numbers in this assay, from the lowest: compounds 1, 3 and 2 (each within the scatter of the next, the first and the last beyond it). At a limit, above all of these: compound 4.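

In this assay compound 4 reads > 100000 nM, which is a limit of the assay and not a number. The earlier compounds shown here offered no pair with this change, and this first one shows that a methoxy group at this place, ortho to a methoxy group and meta to a large group, cannot be traded for hydrogen without a clear loss, with an at least 8.5-fold higher number from compound 1 to compound 4 (0.93 log units; beyond the scatter). That step is only a minimum, because it rests on this: the limit of > 100000 nM in this assay, at which 1 of the 4 values shown sits.

From the compounds shown here alone, whether the loss follows from the missing oxygen or from the whole methoxy group stays open, since only methoxy and hydrogen are seen at this place. A hydroxyl, a methyl or an amine there could separate these two readings, and could show how much of the activity of compound 1 this place can keep.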